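Aryl exchange on the shared core: compound 2 to compound 3

A few compounds are considered here, and "the series" means these few. Any claim that something is new, unique, unknown or untested is made for them only; others in the source may bear on it.

Measured compounds:
compound 1 `CC(C(=O)NCc1ccc(C(F)(F)F)cc1SCc1ccccc1)c1ccc(NS(C)(=O)=O)c(F)c1`, 0.5 nM
compound 2 `CC(C(=O)NCc1ccc(C(F)(F)F)cc1-c1ccc(F)c(Cl)c1)c1ccc(NS(C)(=O)=O)c(F)c1`, 0.6 nM

Both compounds share one core and differ only in the group on the aromatic carbon that carries the side aryl. In an assay on CHO cells for antagonist activity at transient receptor potential cation channel subfamily V member 1 (Homo sapiens), read by FLIPR (on this read-out higher numbers stand for weaker inhibition and lower numbers for stronger inhibition), compound 1 gives 0.5 nM and compound 2 gives 0.6 nM; the step of a 1.2-fold higher number from compound 1 to compound 2 (0.08 log units; within the scatter) shows that putting 3-chloro-4-fluorophenyl in place of benzylsulfanyl moves nothing beyond the scatter, so compound 2 stands level with compound 1 on the two numbers seen so far.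

Compound 3 `COc1ccc(-c2cc(C(F)(F)F)ccc2CNC(=O)C(C)c2ccc(NS(C)(=O)=O)c(F)c2)cc1OC` carries the change (3,4-dimethoxyphenyl in place of 3-chloro-4-fluorophenyl on an aromatic carbon). For the measured compounds named here, the only step that bears on it is a 1.2-fold higher number from compound 1 to compound 2 (0.08 log units; within the scatter), which shows this position accepting two unrelated groups without a shift beyond the scatter. Going by the values given here, on that basis the expected step of a 1.7-fold higher number from compound 2 to compound 3 (0.22 log units; within the scatter) is small, with no clear direction, though a mild weakening cannot be excluded since only one step informs it. Compound 3 is therefore estimated at 1 nM in this assay, with a range from 0.3 nM to 5 nM.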

Compound 3, inhibition constant: 8.6 nM
Compound 3: the middle estimate sits 8.6-fold (0.93 log units) below what was measured; measured number outside the range, above it.
By their numbers in this assay, from the lowest: compounds 1 and 2 (each within the scatter of the next); then compound 3.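

In this assay the aromatic carbon ortho to a large group and meta to a trifluoromethyl group no longer looks indifferent to its substituent: 3,4-dimethoxyphenyl in place of 3-chloro-4-fluorophenyl gives a 14-fold higher number from compound 2 to compound 3 (1.16 log units; beyond the scatter) and thus a large step between two phenyl groups. In place of benzylsulfanyl, the same group gives a 17-fold higher number from compound 1 to compound 3 (1.24 log units; beyond the scatter) and so a large step as well. The level pair of compound 1 and compound 2 therefore marks no general tolerance here, since compound 3 goes against it, and no measurement on hand explains the step.

The compounds shown leave open whether the step follows the two methoxy groups together or only one of them. A 3-methoxyphenyl or a 4-methoxyphenyl group on this carbon would separate these two readings.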